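The compounds below may be only part of what the source reports. "The series", "measured", "known", "first", "only" and "open" are said of these compounds alone.

The measured compounds and their values:

Compound 1, `CCOc1cc(Cl)c(C(=O)NC(=O)Nc2nc3ccc(CN4CCN(C)CC4)cc3s2)cc1-n1cccn1`, in a functional assay on CHO cells for agonist activity at hydroxycarboxylic acid receptor 1 (Homo sapiens), read by cAMP accumulation (a higher number here means that more compound is needed for the effect, a lower number that less compound is needed), gives 19 nM.
Compound 2, `CCOc1cc(Cl)c(C(=O)NC(=O)Nc2nc3ccc(CN4CCN(C)CC4)cc3s2)cc1-n1cccc1`, in this assay gives 22 nM.

Compound 2 holds the higher of the two numbers, but the gap to compound 1 is small: a 1.2-fold higher number from compound 1 to compound 2 (0.06 log units; within the scatter). That single step is the only measured one, and it swaps one five-membered ring for another at the same aromatic carbon without moving the number beyond the scatter.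

Compound 3, `CCOc1cc(Cl)c(C(=O)NC(=O)Nc2nc3ccc(CN4CCN(C)CC4)cc3s2)cc1-c1ccn[nH]1`, has not been measured. It differs from compound 2 in the same place: 1H-pyrazol-5-yl in place of 1H-pyrrol-1-yl on an aromatic carbon. The entering group brings one hydrogen-bond donor that neither measured compound carries, and it is joined through a carbon rather than a nitrogen, so the measured step from compound 1 to compound 2 covers the position but not this exact kind of exchange. Because that step a 1.2-fold higher number from compound 1 to compound 2 (0.06 log units; within the scatter) stayed within the scatter, the tolerance of this position to a five-membered ring argues for no large shift, and the expected step is a 1.1-fold higher number from compound 2 to compound 3 (0.06 log units; within the scatter). Compound 3 is therefore estimated at 25 nM, within a range of 8 nM to 80 nM.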

Compound 3, half-maximal effective concentration in the hydroxycarboxylic acid receptor 1 assay: 360 nM
Estimate against measurement, compound 3: 14-fold (1.16 log units) below; measured number above the stated range.
By their numbers in the hydroxycarboxylic acid receptor 1 assay, from the lowest: compounds 1 and 2 (each within the scatter of the next); then compound 3.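

In the hydroxycarboxylic acid receptor 1 assay, this position does not treat all five-membered aromatic rings alike, although the two rings joined through nitrogen had stayed within the scatter of each other: compound 3, with 1H-pyrazol-5-yl, gives 360 nM, which is a 16-fold higher number from compound 2 to compound 3 (1.21 log units; beyond the scatter) and, measured against the other nitrogen-joined ring, a 19-fold higher number from compound 1 to compound 3 (1.28 log units; beyond the scatter) as well. The heavy-atom count stays the same across the exchange, so ring size alone does not set the number here, while the entering group differs from 1H-pyrrol-1-yl in carrying 1 hydrogen-bond donor, in having 2 hetero atoms in the ring and in being joined through carbon, and this one step cannot separate those differences. In a physicochemical assay for lipophilicity, at pH 7.4 (on this read-out lower numbers stand for lower lipophilicity and higher numbers for higher lipophilicity), compound 2 gives 4 and compound 3 gives 3.9; the same exchange gives a number 0.10 log units lower from compound 2 to compound 3 (within the scatter) and so stays within the scatter, which means the large step at the receptor comes without a matching step on that read-out.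

Still open, going by these compounds, is whether the ring hydrogen on nitrogen or the carbon attachment goes with the higher number, a question that a 1-methyl-1H-pyrazol-5-yl or a thiophen-2-yl group at this position would address. The data shown offer no measured explanation for the size of the step.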